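A few compounds are considered here, and "the series" means these few. Any claim that something is new, unique, unknown or untested is made for them only; others in the source may bear on it.

Measured in a functional assay (Homo sapiens) for antiproliferative activity; on this read-out higher numbers stand for weaker inhibition of growth and lower numbers for stronger inhibition of growth:
- compound 1 `Cc1cn2c(/C=N/NC(=N)N)c(-c3ccncc3)nc2s1`: 47900 nM
- compound 2 `N=C(N)N/N=C/c1c(-c2ccccn2)nc2sc(Cl)cn12`: 20900 nM
- compound 3 `N=C(N)N/N=C/c1c(-c2cccnc2)nc2sc(Cl)cn12`: 46800 nM

Compound 3 lies within the scatter of compound 1, and its number is higher than that of compound 2, beyond the scatter. Next is compound 4 `N=C(N)N/N=C/c1c(-c2ccncc2)nc2sc(Cl)cn12`, with pyridin-4-yl in place of pyridin-3-yl on an aromatic carbon. Among the measured compounds shown here, the only measured step between pyridinyl isomers, a 2.2-fold higher number from compound 2 to compound 3 (0.35 log units; beyond the scatter), is modest. Compound 1 already carries pyridin-4-yl, on a differently substituted core, and gives 47900 nM. No shift beyond the scatter is therefore expected in this assay. The expected step is a 1.1-fold lower number from compound 3 to compound 4 (0.05 log units; within the scatter). Compound 4 is estimated at 42000 nM, with an expected range of 22000 nM to 80000 nM.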

Compound 4, concentration for total growth inhibition: 40700 nM
The estimate for compound 4 lay 1.0-fold (0.01 log units) above the measured number; measured number inside the range.
By their numbers in this assay, from the lowest: compounds 2, 4, 3 and 1 (each within the scatter of the next, the first and the last beyond it).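

In this assay, pyridin-4-yl and pyridin-3-yl cannot be told apart (a 1.1-fold lower number from compound 3 to compound 4 (0.06 log units; within the scatter)), and the step from pyridin-2-yl to pyridin-4-yl also stays inside the scatter (a 1.9-fold higher number from compound 2 to compound 4 (0.29 log units; within the scatter)), so only pyridin-3-yl is separated from pyridin-2-yl. With pyridin-4-yl on the aromatic carbon, chloro in place of methyl likewise leaves the number unresolved (a 1.2-fold lower number from compound 1 to compound 4 (0.07 log units; within the scatter)). No measurement here accounts for these readings.

Open, from the compounds shown here alone, is how a phenyl ring or an aminopyridinyl group would read at this position. Also open, going by these compounds, is whether chloro and methyl stay indistinguishable with pyridin-2-yl.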